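Replacing the biaryl amide tail with a small ring

The source may report more compounds than this note shows. Statements on the series, on what has been measured and on what is new or still open speak of the compounds shown alone.

The series centres on a shared core carrying a hexafluoro-2-hydroxypropan-2-yl group and a phenol. Compound 1 `O=C(COc1ccc2cc(C(O)(C(F)(F)F)C(F)(F)F)c(O)cc2c1)Nc1ccc(-c2ccccc2)cc1` has the lowest number among the two measured values in an assay on isolated protein for inhibition of tyrosine-protein phosphatase non-receptor type 13 (Homo sapiens), read by spectrophotometry; a higher number here means a weaker inhibitor, a lower number a stronger inhibitor: compound 1 gives 2800 nM. Compound 2 `Oc1c(-c2ccccc2)cccc1C(O)(C(F)(F)F)C(F)(F)F`, a far smaller molecule, gives 449000 nM in this assay, a much higher number and beyond the scatter. Compound 3 `Oc1c(C(O)(C(F)(F)F)C(F)(F)F)ccc2ccccc12` reaches only the assay limit, > 500000 nM, and so yields no number; this is the situation described by the limit of > 500000 nM in this assay, at which 1 of the 3 values shown sits.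

Compound 4 `O=C(COc1ccc2cc(C(O)(C(F)(F)F)C(F)(F)F)c(O)cc2c1)NC1CC1` keeps the core of compound 1 and the amide linker but differs at the amide-type nitrogen: cyclopropyl in place of 4-phenylphenyl on an amide-type nitrogen. Among the compounds with values here, no step between measured compounds matches this change, so the expectation rests on what the two measured numbers show. Because compound 2 gives 449000 nM where the core stands without any extended tail, the extended tail of compound 1 appears to carry much of its potency, and the small cyclopropyl is expected to recover only part of it. The author therefore expects a sizable weakening in this assay, with the step of an 11-fold higher number from compound 1 to compound 4 (1.03 log units; beyond the scatter). Compound 4 is estimated at 30000 nM, within a range from 8000 nM to 120000 nM.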

Compound 4, half-maximal inhibitory concentration: > 20000 nM
Compound 4: a limit, no number (the forecaster's own chance of this, stated with the estimate: 10%); the middle value is on the limit's open side.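

In this assay, compound 4 reaches only a limit of the assay, > 20000 nM, and so gives no number. Compounds 1 and 4 are the only pair shown that differ in one place, and with the shared core and the amide linker kept, cyclopropyl in place of 4-phenylphenyl on the amide-type nitrogen gives an at least 7.1-fold higher number from compound 1 to compound 4 (0.85 log units; beyond the scatter), so this change alone is enough to move the result beyond the scatter, which compounds 2 and 3 could not show, as they differ from compound 1 in more than one place. The full size of the step cannot be read because compound 4 sits at a limit: the limit of > 20000 nM in this assay, at which 1 of the 4 values shown sits.

The two groups differ at once in ring type, ring count and heavy atoms, so the compounds shown leave open whether the gain in compound 1 needs both aromatic rings of the 4-phenylphenyl or only a larger group on this nitrogen. A benzyl group or a straight hexyl chain at this place would begin to separate these readings, and a carboxylic acid on the far ring of the tail would test how much change that ring accepts.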